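Notes on compound 3: methoxy in place of fluoro

The source may report more compounds than this note shows. Statements on the series, on what has been measured and on what is new or still open speak of the compounds shown alone.

- compound 1 `COc1ccc(/C=C/C(=O)Nc2cc(-c3ccc(Br)cc3)[nH]n2)cc1`: 590 nM
- compound 2 `Cc1ccc(-c2cc(NC(=O)/C=C/c3ccc(F)cc3)n[nH]2)cc1`: 950 nM

In a functional assay on MCF7 cells (Homo sapiens) for antiproliferative activity, read by MTT assay, with a stated time of 48 h (a lower number here means a stronger inhibitor, a higher number a weaker inhibitor), compound 2 stands at 950 nM within the scatter of compound 1. Compound 3 `COc1ccc(/C=C/C(=O)Nc2cc(-c3ccc(C)cc3)[nH]n2)cc1` differs from compound 2 by methoxy in place of fluoro on an aromatic carbon with methoxy in place of fluoro on an aromatic carbon. Among the compounds with values here, no measured pair isolates this change. No shift beyond the scatter is expected, since compound 1 carries the same 4-methoxyphenyl group and gives 590 nM within the scatter of compound 2. The expected step of a 1.4-fold lower number from compound 2 to compound 3 (0.13 log units; within the scatter) is small. For compound 3 the estimate is 700 nM with an expected range from 300 nM to 1600 nM in this assay for now.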

Compound 3, half-maximal inhibitory concentration: 860 nM
The estimate for compound 3 lay 1.2-fold (0.09 log units) below the measured number; the measured number falls inside the stated range.
By their numbers in this assay, from the lowest: compounds 1, 3 and 2 (each within the scatter of the next).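

Exchanging 4-fluorophenyl for 4-methoxyphenyl now stands as a directly measured change, giving a 1.1-fold lower number from compound 2 to compound 3 (0.04 log units; within the scatter) in this assay. With 4-methoxyphenyl held fixed, methyl in place of bromo on an aromatic carbon gives a 1.5-fold higher number from compound 1 to compound 3 (0.16 log units; within the scatter), so neither single change moves the number beyond the scatter. Nothing available accounts for either step.

From the compounds shown here alone, whether an amine or a carboxylic acid at either of these positions would shift the number beyond the scatter remains open. The compounds shown also leave open how changes to the shared core would read.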